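A few compounds are considered here, and "the series" means these few. Any claim that something is new, unique, unknown or untested is made for them only; others in the source may bear on it.

Measured so far in an assay on isolated protein for inhibition of microsomal triglyceride transfer protein large subunit (Homo sapiens); a lower number here means a stronger inhibitor, a higher number a weaker inhibitor:
- compound 1 `COC(=O)N[C@H]1Cc2ccc(NC(=O)c3cc(C(F)(F)F)ccc3-c3ccc(C(F)(F)F)cc3)cc2C1`: 410 nM
- compound 2 `Cc1ccc(-c2c(C)cccc2C(=O)Nc2ccc3c(c2)CC(NS(=O)(=O)c2ccccc2)C3)cc1`: 93 nM
- compound 3 `Cc1cccc(C(=O)Nc2ccc3c(c2)CC(NS(C)(=O)=O)C3)c1-c1ccc(Cl)cc1`: 100 nM

Compound 3 stands second highest of the three numbers. Its nearest neighbour is compound 2, whose number lies within the scatter of that of compound 3, so no order between the two can be read. The furthest is compound 1, whose number is beyond the scatter and clearly higher than that of compound 3.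

Compound 4 `COC(=O)NCC1Cc2ccc(NC(=O)c3cccc(C)c3-c3ccc(Cl)cc3)cc2C1` differs from compound 3 in one place: ((methoxycarbonyl)amino)methyl in place of methanesulfonamido on a saturated ring carbon. Going by the values given here, no measured pair shows this exact exchange, so the size of the step is not known from the series. Compound 1 carries a related carbamate group on the same saturated ring carbon, without the methylene, on a different aryl part, and gives the highest number of the three; this is the only hint, and it points toward a weaker rather than a stronger inhibitor. The step from compound 3 to compound 4 is therefore expected to be a moderate rise, a 2.2-fold higher number from compound 3 to compound 4 (0.34 log units; beyond the scatter), with wide uncertainty. Compound 4 is estimated at 220 nM, in the range 60 nM to 800 nM.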

Compound 4, half-maximal inhibitory concentration: 100 nM
The estimate for compound 4 lay 2.2-fold (0.34 log units) above the measured number, within the range that was stated.
By their numbers in this assay, from the lowest: compounds 2, 3 and 4 (each within the scatter of the next); then compound 1.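

In this assay, replacing methanesulfonamido with ((methoxycarbonyl)amino)methyl on the saturated ring carbon gives no change at the digits printed from compound 3 to compound 4 (within the scatter). Going by these compounds alone, this is the first one-place step, and it shows that, on the core shared by this pair, the position accepts either group without a readable shift in the number, despite the different chain and the loss of the sulfur. No independent measurement bears on this result.

Still open, from the compounds shown here alone, is how the position responds to groups of another kind, such as a primary amine, a carboxylic acid or a longer chain ending in the same carbamate. The effect of the methylene alone also remains unresolved, as compound 1 differs from compound 4 in more than one place.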